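Azidobenzoyl in Place of Azidonitrophenyl on the Cyanoguanidine Side Chain

The compounds below may be only part of what the source reports. "The series", "measured", "known", "first", "only" and "open" are said of these compounds alone.

Compound 1, `N#CN/C(=N\CCNc1ccc(N=[N+]=[N-])cc1[N+](=O)[O-])NCCCCOc1cccc(CN2CCCCC2)c1`: 7.47
Compound 2, `N#CN/C(=N\CCNC(=O)c1ccccc1)NCCCOc1cccc(CN2CCCCC2)c1`: 7.82

Both compounds were tested in a functional assay on cardiac atrium for antagonist activity at histamine H2 receptor (Cavia porcellus), tested at 0.3 uM; a lower number here means a less potent compound, a higher number a more potent compound, by a factor of ten per unit of this negative logarithm. Compound 1 has the lower of the two numbers, and compound 2 stands higher by a gap that lies beyond the usual scatter. Going by the values given here, the two differ in more than one place, so no single step connects them; their values only show that compound 2 comes out higher.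

Compound 3, `N#CN/C(=N\CCNC(=O)c1ccc(N=[N+]=[N-])cc1)NCCCCOc1cccc(CN2CCCCC2)c1`, has not yet been measured. It arises from compound 1 by one change: (4-azidophenyl)carbonyl in place of 4-azido-2-nitrophenyl on an amine nitrogen. Compound 2 also carries a carbonyl on the corresponding nitrogen and gives 7.82 in this assay. Among the compounds with values here, no measured pair isolates this change, so the expectation rests on compound 2 alone. The step from compound 1 to compound 3 is expected to be a number 0.28 log units higher from compound 1 to compound 3 (within the scatter), a modest rise. Compound 3 is estimated at 7.75, with a range from 7.3 to 8.2.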

Compound 3, negative logarithm of the antagonist equilibrium constant: 7.54
Compound 3: middle estimate off by 0.21 log units, on the high side; the range from low to high includes it.
By their numbers in this assay, from the lowest: compounds 1, 3 and 2 (each within the scatter of the next, the first and the last beyond it).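

In this assay, placing (4-azidophenyl)carbonyl in place of 4-azido-2-nitrophenyl on the amine nitrogen gives a number 0.07 log units higher from compound 1 to compound 3 (within the scatter), so the two groups cannot be told apart in this measurement. Going by these compounds alone, this is the first direct reading at this position, and it shows that a group joined through a carbonyl and a nitro-bearing aromatic group joined directly to the nitrogen can give matching potency. Nothing measured here explains this match.

From the compounds shown here alone, this change removes the nitro group and adds the carbonyl at once, so their separate contributions remain open; a plain 4-azidophenyl group on the same nitrogen would help separate them. Also open, going by these compounds, is whether the azido group itself matters, which an amine or a methoxy group in its place could test.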